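Sulfamoyl in place of cyano: expected potency of compound 3

This account rests on a few compounds, and the source may have more. Where it says the series, first, only, none or still open, it means among the compounds named here.

Measured so far in an assay on HeLa cells for inhibition of Indoleamine 2,3-dioxygenase 1 (Homo sapiens), read by spectrophotometry, with a stated time of 24 h; a lower number here means that less compound is needed, a higher number that more compound is needed for the effect:
compound 1 `CC(=O)Nc1ccc(S(=O)(=O)NNc2ccccc2)cc1` gives > 10000 nM, which is a limit of the assay, not a number.
compound 2 `CC(=O)Nc1ccc(S(=O)(=O)NNc2ccc(C#N)cc2)cc1` gives 1390 nM.

Compound 2 holds the only number shown in this assay. The other value sits at the limit of > 10000 nM in this assay, at which 1 of the 2 values shown sits. Compound 3 `CC(=O)Nc1ccc(S(=O)(=O)NNc2ccc(S(N)(=O)=O)cc2)cc1` differs from compound 2 by sulfamoyl in place of cyano on an aromatic carbon. Among the compounds with values here, the one measured step, an at least 7.1-fold lower number from compound 1 to compound 2 (0.85 log units; beyond the scatter), concerns cyano entering where hydrogen stood, and bears only loosely on exchanging one group for another at the same place; in this assay a step of modest size in either direction, or none beyond the scatter, is plausible. The estimate for compound 3 is 2500 nM, within 700 nM to 9000 nM. This estimate means that a 1.8-fold higher number from compound 2 to compound 3 (0.25 log units; within the scatter) is expected.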

Compound 3, half-maximal effective concentration: 3120 nM
Estimate against measurement, compound 3: 1.2-fold (0.10 log units) below; the measured number falls inside the stated range.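

With an at least 3.2-fold lower number from compound 1 to compound 3 (0.50 log units; beyond the scatter) for sulfamoyl in place of hydrogen, a second group besides cyano now gives a lower number at this place. With a 2.2-fold higher number from compound 2 to compound 3 (0.35 log units; beyond the scatter) for sulfamoyl in place of cyano, the two groups are also separated from each other, and cyano gives the lower number. The value of compound 1 is a limit of the assay, not a number: the limit of > 10000 nM in this assay, at which 1 of the 3 values shown sits.

Open, on these data alone, is whether an amine, a carboxylic acid or a methyl ester at this place would give a number lower than that of compound 2. Also open, as far as these compounds go, is how either group behaves elsewhere on the ring.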